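The source may hold more compounds than are shown below. What is called first, only, known or untested is meant among the compounds shown, and "the series" means these compounds.

Working notes on the series.

Three compounds have numbers in an ADME assay on liver for metabolic stability, with Liver microsome (Homo sapiens) as the target, using microsomes and NADPH, with a stated time of 30 min, tested at 0.5 uM; a lower number here means slower removal, a higher number faster removal of the compound. Compound 1 `O=C1C2CN(Cc3ccccc3)CC2CN1c1cccc2c1cnn2-c1ccccc1F` gives 900 mL/min/kg in this assay. Compound 2 `O=C1NCCN1CCOc1nn(-c2ccccc2F)c2ccc(F)cc12` gives 183 mL/min/kg in this assay. Compound 3 `O=C1NCCN1CCOc1nn(-c2ccc(F)cc2)c2ccc(F)cc12` gives 66.7 mL/min/kg in this assay, the lowest of the three numbers; compound 2 is the nearest to it and compound 1 the furthest. Within the data shown here, the one single-point step so far, a 2.7-fold lower number from compound 2 to compound 3 (0.44 log units; beyond the scatter), concerns the aryl on the aromatic nitrogen.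

Compound 4 `O=C1NCCN1CCOc1nn(-c2ccc(F)cc2F)c2ccc(F)cc12` differs from compound 3 by fluoro in place of hydrogen on an aromatic carbon; the same change read one bond further out is 4-fluorophenyl to 2,4-difluorophenyl. The step of a 2.7-fold lower number from compound 2 to compound 3 (0.44 log units; beyond the scatter) bears on it, since it removed a fluoro from the 2-position of that aryl and lowered the number beyond the scatter; compound 4 brings a fluoro back to that ring while keeping the 4-fluoro. For compound 4 the expected step is therefore a partial return toward compound 2, a 1.6-fold higher number from compound 3 to compound 4 (0.22 log units; within the scatter), though a move within the scatter cannot be excluded. Compound 4 is estimated at 110 mL/min/kg in this assay, with a range from 55 mL/min/kg to 220 mL/min/kg.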

Compound 4, clearance: 150 mL/min/kg
Estimate against measurement, compound 4: 1.4-fold (0.13 log units) below; measured number inside the range.
By their numbers in this assay, from the lowest: compound 3; then compounds 4 and 2 (each within the scatter of the next); then compound 1.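

In this assay, fluoro in place of hydrogen on the aromatic carbon ortho to a large group, with the 4-fluoro kept, gives a 2.2-fold higher number from compound 3 to compound 4 (0.35 log units; beyond the scatter), so this position can now be read on its own rather than only through the swap of one fluoro for another. Going from 2-fluorophenyl to 2,4-difluorophenyl gives a 1.2-fold lower number from compound 2 to compound 4 (0.09 log units; within the scatter), so among compounds 2, 3 and 4 the step beyond the scatter follows the fluoro at this position, while the added 4-fluoro does not move the number beyond the scatter. Nothing at hand gives a reason for either step.

On these data alone, whether a chloro, methyl or methoxy group at this position would give a similar step remains open. The same holds for a plain phenyl on the aromatic nitrogen, which would show what the 4-fluoro contributes without any other fluoro on that ring.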